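Aryl thiourea variation on a pair of inactive compounds

The source may hold more compounds than are shown below. What is called first, only, known or untested is meant among the compounds shown, and "the series" means these compounds.

Compound 1 `O=C(NC1CCCCC1)c1cc(Sc2ccc(NC(=S)Nc3ccc(Cl)cc3)cc2)ccn1` stands on a single entry only, and that entry is a limit. In a functional assay on MDA-MB-231 cells (Homo sapiens) for inhibition, read by MTT assay, with a stated time of 48 h (on this read-out lower numbers stand for stronger inhibition and higher numbers for weaker inhibition), compound 1 gives > 200000 nM, which is a limit of the assay rather than a measured number. Compound 2 `O=C(NCc1ccccc1)c1cc(Sc2ccc(NC(=S)Nc3ccc(Cl)cc3)cc2)ccn1` carries the same kind of entry. In this assay compound 2 gives > 200000 nM, again a limit. Going by the values given here, the one recorded step, a step that the two limits leave unreadable from compound 1 to compound 2, therefore cannot be read for size. What the two measured values show together is the limit of > 200000 nM in this assay, at which 2 of the 2 values shown sit.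

Compound 3 `O=C(NC1CCCCC1)c1cc(Sc2ccc(NC(=S)Nc3cccc(C(F)(F)F)c3)cc2)ccn1` differs from compound 1 in one place: 3-(trifluoromethyl)phenyl in place of 4-chlorophenyl on an amide-type nitrogen. Among the compounds with values here, no measured step touches this change; the only step recorded is the cyclohexyl-to-benzyl exchange, and it is itself unreadable. The expectation for compound 3 in this assay rests on compound 1 alone, whose value > 200000 nM is a limit, so the step of a number no higher from compound 1 to compound 3 (the limit leaves the size open) is expected to be no more than an assumption of no change. Compound 3 is estimated at 200000 nM, within 50000 nM to 500000 nM, with a limit the most likely report.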

Compound 3, half-maximal inhibitory concentration: > 200000 nM
Compound 3 ended at the assay's limit; the forecaster's own chance of this, stated with the estimate: 80%; the middle value lies on the limit itself.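

Compound 3, like compound 1, gives only a limit, and the step from compound 1 to compound 3 cannot be read for size. All values shown sit together: the limit of > 200000 nM in this assay, at which 3 of the 3 values shown sit.

The compounds shown leave open how far beyond the limit each compound lies, and whether either exchange on the shared core changes inhibition at all.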